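Dropping the Ethoxy Group from a Pyridine Carboxamide

The source may hold more compounds than are shown below. What is called first, only, known or untested is meant among the compounds shown, and "the series" means these compounds.

Measured compounds:
Compound 1, `COc1cccc(-c2cc(Cl)cc(C(=O)Nc3nn[nH]n3)n2)c1`, gives 95%.
Compound 2, `CCOc1cc(C(=O)Nc2nn[nH]n2)nc(-c2ccc(N)cc2)c1`, gives 62%.

Both compounds were tested in a functional assay on the whole organism with Rattus norvegicus as the target, at a dose of 3 mg/kg by the oral route; on this read-out lower numbers stand for a weaker effect and higher numbers for a stronger effect at the one dose given. Compound 2 stands lowest of the two numbers; its nearest neighbour is compound 1, whose value lies higher by a margin beyond the usual scatter. Within the data shown here, no pair of measured compounds differs in only one place, so no single change can yet be tied to a shift in effect.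

Compound 3, `Nc1ccc(-c2cccc(C(=O)Nc3nn[nH]n3)n2)cc1`, has not been measured. It differs from compound 2 by hydrogen in place of ethoxy on an aromatic carbon. Among the measured compounds shown here, with no comparable step among the measured compounds, the expected size of the step can only be guessed. The expectation is a drop, possibly beyond the scatter: a number 17 percentage points lower from compound 2 to compound 3 (beyond the scatter) is estimated from compound 2 alone. Compound 3 is therefore expected to give about 45%, within a range from 15% to 75%.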

Compound 3, a percentage reported as inhibition, in the whole organism at one dose (the size of the read-out at that dose, not a potency): 81%
Beside the measured number, compound 3's estimate is 36 percentage points below it, and the stated range ends below it.
By their numbers in this assay, from the lowest: compound 2; then compound 3; then compound 1.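

Among these compounds, compound 2 and compound 3 form the first pair here that differs in one place, so a change in effect can now be tied to a single change. In this assay, putting hydrogen in place of the ethoxy group, on the carbon opposite the ring nitrogen, gives a number 19 percentage points higher from compound 2 to compound 3 (beyond the scatter), so on this core ethoxy is not needed at this position for an effect at the one dose given. No measurement of any other property accompanies this step, so the reason for it stays unknown.

As far as these compounds go, whether a methyl group, an amine or a longer chain such as propoxy at this carbon would give a number closer to hydrogen or to ethoxy remains open. This single pair also cannot show whether the same swap would act alike on a different core.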